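Swapping 2-fluoro-5-nitrophenyl for 1,3-thiazol-2-yl on the amide

This account rests on a few compounds, and the source may have more. Where it says the series, first, only, none or still open, it means among the compounds named here.

Two amides on a shared core have been tested so far in a functional assay on A549 cells (Homo sapiens) for cytotoxicity, read by MTT assay; a higher number here means a weaker inhibitor, a lower number a stronger inhibitor. Compound 1 `CCn1cc(C(=O)Nc2ccc(C)c([N+](=O)[O-])c2)c(=O)c2cc(F)c(N3CCNC(C)C3)c(F)c21` gives 3700 nM, and compound 2 `CCn1cc(C(=O)Nc2cc([N+](=O)[O-])ccc2F)c(=O)c2cc(F)c(N3CCNC(C)C3)c(F)c21` gives 1700 nM. For the measured compounds named here, the only measured step is a 2.2-fold lower number from compound 1 to compound 2 (0.34 log units; beyond the scatter), modest but beyond the scatter, which leaves compound 2 with the lower of the two numbers.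

Compound 3 `CCn1cc(C(=O)Nc2nccs2)c(=O)c2cc(F)c(N3CCNC(C)C3)c(F)c21` keeps the shared core but carries 1,3-thiazol-2-yl in place of 2-fluoro-5-nitrophenyl on the amide-type nitrogen: 1,3-thiazol-2-yl in place of 2-fluoro-5-nitrophenyl on an amide-type nitrogen. The measured step bears on this change only loosely. Going by the values given here, it exchanged one phenyl group for another at the same place, whereas here the six-membered ring is lost, and no tested compound shows the effect of that. The step of a 2.2-fold lower number from compound 1 to compound 2 (0.34 log units; beyond the scatter) does suggest that this place can move the number by a modest amount, so a change of similar or somewhat larger size seems reasonable. Starting from the lower of two numbers, the likelier direction is upward, although this is uncertain. The expected change is a 2.4-fold higher number from compound 2 to compound 3 (0.37 log units; beyond the scatter), toward a weaker inhibitor. For compound 3 the estimated value is 4000 nM, with an expected range of 1200 nM to 15000 nM.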

Compound 3, half-maximal inhibitory concentration: 20200 nM
The estimate for compound 3 lay 5.1-fold (0.70 log units) below the measured number; the measured number lies above the stated range.
By their numbers in this assay, from the lowest: compound 2; then compound 1; then compound 3.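

In this assay the exchange of a substituted phenyl on the amide-type nitrogen for 1,3-thiazol-2-yl proved far from neutral: replacing 2-fluoro-5-nitrophenyl gives a 12-fold higher number from compound 2 to compound 3 (1.07 log units; beyond the scatter) as a large step toward a weaker inhibitor, and replacing 4-methyl-3-nitrophenyl gives a 5.5-fold higher number from compound 1 to compound 3 (0.74 log units; beyond the scatter) in the same direction. The earlier exchange of one phenyl group for another, a 2.2-fold lower number from compound 1 to compound 2 (0.34 log units; beyond the scatter) in this assay and modest in size, had shown only that this place can move the number; the new compound shows that it can move it much further, and that both phenyl amides shown give lower numbers than the 1,3-thiazol-2-yl amide. Nothing measured here accounts for the size of this rise.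

The compounds shown do not separate the loss of the six-membered ring, the fewer heavy atoms and the loss of the nitro group as contributors to the change. From the compounds shown here alone, an unsubstituted phenyl, a pyridin-2-yl or a 1,3-thiazol-2-yl carrying a nitro group on the same amide-type nitrogen would each bear on that question, and how any of them would read remains open.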